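A few compounds are considered here, and "the series" means these few. Any claim that something is new, unique, unknown or untested is made for them only; others in the source may bear on it.

Measured so far:
- compound 1 `C[C@@H]1C[C@H](c2nc(-c3ccc4ccccc4n3)no2)CCN1C(=O)Nc1ccccc1Cl`, which in a functional assay on Shh Light II cells (Mus musculus) for inhibition, read by a luciferase reporter (a lower number here means a stronger inhibitor, a higher number a weaker inhibitor), gives 2400 nM
- compound 2 `O=C(Nc1ccccc1Cl)N1CCN(c2nc(-c3ccc4ccccc4n3)no2)CC1`, which in this assay gives 140 nM

Compound 2 stands at the lowest of the two numbers in this assay. Going by the values given here, the only other measured compound is compound 1, whose number lies well beyond the scatter above that of compound 2, so compound 2 is the stronger inhibitor of the two on these figures; the two differ in more than one place, so no single step can be read from them.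

The next compound is compound 3 `O=C(NC1CCCCC1)N1CCN(c2nc(-c3ccc4ccccc4n3)no2)CC1`. It differs from compound 2 in one place: cyclohexyl in place of 2-chlorophenyl on an amide-type nitrogen. Among the compounds with values here, no measured pair in the set carries this change, so the size of its effect in this assay is open. The expectation is a step from compound 2 to compound 3 of a 3.6-fold higher number from compound 2 to compound 3 (0.55 log units; beyond the scatter), towards a weaker inhibitor, of a size probably beyond the scatter but with wide uncertainty. On that basis compound 3 is estimated at 500 nM in this assay, with a plausible range from 150 nM to 2000 nM.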

Compound 3, half-maximal inhibitory concentration: 53 nM
Compound 3: the middle estimate sits 9.4-fold (0.97 log units) above what was measured; measured number outside the range, below it.
By their numbers in this assay, from the lowest: compound 3; then compound 2; then compound 1.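

The amide-type nitrogen of this series does not need an aromatic ring for inhibition in this assay: cyclohexyl in place of 2-chlorophenyl gives a 2.6-fold lower number from compound 2 to compound 3 (0.42 log units; beyond the scatter) and this modest step lies beyond the scatter. Going by these compounds alone, this is the first step that can be read at a single place, and it shows that, in this pair, neither the aromatic ring nor the chlorine is required at this position for the stronger number. No measurement is available that bears on what lies behind this step, so it stands as an observation on this one pair.

Phenyl without chlorine is not among the compounds shown, so the contributions of the chlorine and of the aromatic ring to the step cannot be separated, and it remains open whether a smaller ring such as cyclopentyl, an open chain such as n-butyl, or a cyclohexyl bearing an amine or a carboxylic acid would fit this position as well. From the compounds shown here alone, it is also open whether the same change would give a step of similar size on the core of compound 1.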